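Ester in place of amide on the shared core

The source may report more compounds than this note shows. Statements on the series, on what has been measured and on what is new or still open speak of the compounds shown alone.

Measured so far:
compound 1 `C#CCNC(=O)c1ccc(C(CC)(CC)c2ccc(OCC(=O)C(C)(C)C)c(C)c2)n1CC` — 2200 nM
compound 2 `CCn1c(C(=O)NCC(OC)OC)ccc1C(CC)(CC)c1ccc(OCC(=O)C(C)(C)C)c(C)c1` — 130 nM
compound 3 `CCn1c(C(=O)N(C)c2ccccc2)ccc1C(CC)(CC)c1ccc(OCC(=O)C(C)(C)C)c(C)c1` — 18500 nM

In an assay on HL-60 cells for agonist activity at vitamin D3 receptor (Homo sapiens), read by microscopy, with a stated time of 96 h (on this read-out lower numbers stand for an effect already at smaller amounts and higher numbers for an effect only at larger amounts of compound), compound 2 stands lowest of the three numbers, with compound 1 nearest and compound 3 furthest. Compound 4 `C#CC(C)OC(=O)c1ccc(C(CC)(CC)c2ccc(OCC(=O)C(C)(C)C)c(C)c2)n1CC` carries the change ((1-methylprop-2-yn-1-yl)oxy in place of (2,2-dimethoxyethyl)amino on a carbonyl carbon). Among the measured compounds shown here, two measured steps bear on it. The step of a 17-fold lower number from compound 1 to compound 2 (1.23 log units; beyond the scatter) shows that replacing a propargyl-type chain on the amide nitrogen by the dimethoxyethyl chain lowers the number strongly, so going back toward a propargyl-type group should raise it. The step of a 140-fold higher number from compound 2 to compound 3 (2.15 log units; beyond the scatter) shows that removing the amide hydrogen, together with a larger substituent, raises the number a great deal; compound 4 also lacks the amide hydrogen, although it carries a smaller group than compound 3. A clearly higher number than compound 2 is therefore expected, probably between the two comparators, in the direction of compound 1 and compound 3. For compound 4 the estimate is 4000 nM, with a range from 800 nM to 20000 nM, corresponding to an expected step of a 31-fold higher number from compound 2 to compound 4 (1.49 log units; beyond the scatter).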

Compound 4, half-maximal effective concentration: 210 nM
Compound 4: the middle estimate sits 19-fold (1.28 log units) above what was measured, and the stated range ends above it.
By their numbers in this assay, from the lowest: compounds 2 and 4 (each within the scatter of the next); then compound 1; then compound 3.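

In this assay the carbonyl carbon accepts an ester as well as an amide: a 1.6-fold higher number from compound 2 to compound 4 (0.21 log units; within the scatter) lies within the scatter, so the amide hydrogen is not required for a low number here. Loss of that hydrogen alone does not account for the high number of compound 3: an 88-fold lower number from compound 3 to compound 4 (1.94 log units; beyond the scatter) separates two groups that both lack it. A triple bond in the group does not fix the number either, as a 10-fold lower number from compound 1 to compound 4 (1.02 log units; beyond the scatter) links two groups that both hold one.

Open, on these data alone, is whether that last step belongs to oxygen in place of nitrogen or to the added methyl, which a plain propargyloxy group would separate, and how a carboxylic acid would read on this carbonyl carbon. No measurement in hand gives a reason for any of these steps.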